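The source may hold more compounds than are shown below. What is called first, only, known or untested is meant among the compounds shown, and "the series" means these compounds.

For the measured compounds named here, in a functional assay on PC-3 cells (Homo sapiens) for antiproliferative activity, read by MTT assay, with a stated time of 48 h (a lower number here means a stronger inhibitor, a higher number a weaker inhibitor), compound 2 `CCn1c(C(=O)Nc2cccc(C(F)(F)F)c2)ccc1C(CC)(CC)c1ccc(OCCC(O)(CC)CC)c(C)c1` gives 23800 nM, the higher of the two numbers so far, while compound 1 `CCn1c(C(=O)NCCCN(C)C)ccc1C(CC)(CC)c1ccc(OCCC(O)(CC)CC)c(C)c1` gives 2150 nM. Compound 3 `CCOC(=O)C(CC(=O)OC)NC(=O)c1ccc(C(CC)(CC)c2ccc(OCCC(O)(CC)CC)c(C)c2)n1CC` differs from compound 2 by a group of 11 heavy atoms (7 carbon, 4 oxygen; no ring) in place of a group of 10 heavy atoms (7 carbon, 3 fluorine; one six-membered aromatic ring of carbon only), on an amide-type nitrogen. Going by the values given here, the only measured step on this amide-type nitrogen is an 11-fold higher number from compound 1 to compound 2 (1.04 log units; beyond the scatter), which is large and beyond the scatter. The entering group matches neither measured group, so that single step is a loose guide. A moderate move to a lower number in this assay is expected, smaller than the measured step. The expected change is a 2.4-fold lower number from compound 2 to compound 3 (0.38 log units; beyond the scatter). Compound 3 is estimated at 10000 nM, with an expected range of 3000 nM to 30000 nM.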

Compound 3, half-maximal inhibitory concentration: 5840 nM
Beside the measured number, compound 3's estimate is 1.7-fold (0.23 log units) above it; the range from low to high includes it.
By their numbers in this assay, from the lowest: compound 1; then compound 3; then compound 2.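

In this assay, the ring-free group of 11 heavy atoms (7 carbon, 4 oxygen) on the amide-type nitrogen gives a 4.1-fold lower number from compound 2 to compound 3 (0.61 log units; beyond the scatter), so a lower number at this position does not require the amine-bearing chain of compound 1. That chain still keeps the lowest number of the three, with a 2.7-fold higher number from compound 1 to compound 3 (0.43 log units; beyond the scatter). Nothing measured here explains either step.

Open, as far as these compounds go, is how a carboxylic acid in the entering group would compare. Also open, from the compounds shown here alone, is where a shorter 2-(dimethylamino)ethyl chain or an unsubstituted phenyl on this nitrogen would fall.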